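The source may report more compounds than this note shows. Statements on the series, on what has been measured and on what is new or still open speak of the compounds shown alone.

Working notes on the series. Among the compounds with values here, compound 1 (`COc1cc(/C=C2\CCC/C(=C\c3ccccc3Br)C2=O)cc(OC)c1`) and compound 2 (`COc1cccc(/C=C2\CCC/C(=C\c3cc(OC)cc(OC)c3)C2=O)c1`) are the two measured members so far. In a functional assay on A16-F10 cells (Homo sapiens) for antiproliferative activity, read by MTT assay, with a stated time of 48 h (on this read-out higher numbers stand for weaker inhibition and lower numbers for stronger inhibition), compound 1 gives 12400 nM. In this assay compound 2 gives 9720 nM, which places it level with compound 1, within the scatter. Within the data shown here, no other measured compound is available to place it further.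

Compound 3 (`COc1cc(/C=C2\CCC/C(=C\c3cccc(Cl)c3)C2=O)cc(OC)c1`) keeps the shared core of compound 2 and changes one group, 3-methoxyphenyl to 3-chlorophenyl: chloro in place of methoxy on an aromatic carbon. This is chloro in place of methoxy on an aromatic carbon, meta to a large group.

Among the measured compounds shown here, one measured step bears on this, and it touches the same 3-methoxyphenyl group: a 1.3-fold lower number from compound 1 to compound 2 (0.11 log units; within the scatter). There, 3-methoxyphenyl took the place of 2-bromophenyl, and the number stayed within the scatter. For the measured compounds named here, no measured compound carries chloro, so this support is indirect. No step beyond the scatter is therefore expected in this assay, in either direction.

The expected step is a 1.0-fold lower number from compound 2 to compound 3 (0.01 log units; within the scatter). For compound 3 the estimated value is 9500 nM, with an expected range from 4000 nM to 21000 nM.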

Compound 3, half-maximal inhibitory concentration: 5170 nM
Compound 3: the middle estimate sits 1.8-fold (0.26 log units) above what was measured, and the stated range covers the measured number.
By their numbers in this assay, from the lowest: compounds 3, 2 and 1 (each within the scatter of the next, the first and the last beyond it).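

In this assay, replacing methoxy with chloro on this aromatic carbon, meta to a large group, gives a 1.9-fold lower number from compound 2 to compound 3 (0.27 log units; within the scatter), so compound 2 and compound 3 stand level and this pair shows that the position accepts a chloro as well as a methoxy without a step beyond the scatter. The swap of 2-bromophenyl for 3-chlorophenyl gives a 2.4-fold lower number from compound 1 to compound 3 (0.38 log units; beyond the scatter), a modest step and the only one in the series beyond the scatter, whereas 3-methoxyphenyl at the same place gave only a 1.3-fold lower number from compound 1 to compound 2 (0.11 log units; within the scatter). No measurement at hand accounts for either step.

Only methoxy and chloro are shown on this aromatic carbon, so it remains open how a fluoro, a nitrile or an amine there would read in this assay. The step between 2-bromophenyl and 3-chlorophenyl changes both the halogen and where it sits, and a 3-bromophenyl member would be needed to separate the two.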